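Swapping the ring at the piperidine nitrogen for an indole

The source may report more compounds than this note shows. Statements on the series, on what has been measured and on what is new or still open speak of the compounds shown alone.

Compound 1 `Fc1ccc(CN2CCC(NCCSC(c3ccc(F)cc3)c3ccc(F)cc3)CC2)cc1` gives 13.3 nM in an assay on membranes from Cortex for displacement of a labelled ligand from Sigma non-opioid intracellular receptor 1 (Cavia porcellus), read by scintillation counting, with a stated time of 120 min (on this read-out lower numbers stand for stronger inhibition and higher numbers for weaker inhibition), the higher of the two numbers recorded so far. Going by the values given here, compound 2 `O=C(c1ccccc1)N1CCC(NCCSC(c2ccc(F)cc2)c2ccc(F)cc2)CC1` gives 2.03 nM in this assay, and the single comparison between them, a 6.6-fold lower number from compound 1 to compound 2 (0.82 log units; beyond the scatter), shows that changing the group on the ring amine nitrogen moves the number by a modest but real amount. Compound 3 `Fc1ccc(C(SCCNC2CCN(Cc3cc4ccccc4[nH]3)CC2)c2ccc(F)cc2)cc1` alters the same position in a different way: 1H-indol-2-yl in place of 4-fluorophenyl on a saturated chain carbon bound to an amine nitrogen in a ring. Among the compounds with values here, no measured pair shows this particular swap, so the one step from compound 1 to compound 2 indicates only that this position tolerates change, not which direction an indole will take. The expectation is therefore a small step, a 1.7-fold lower number from compound 1 to compound 3 (0.22 log units; within the scatter), with a wide margin. Compound 3 is estimated at 8 nM in this assay, expected to fall between 2 nM and 35 nM.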

Compound 3, inhibition constant: 205 nM
Estimate against measurement, compound 3: 26-fold (1.41 log units) below; measured number above the stated range.
By their numbers in this assay, from the lowest: compound 2; then compound 1; then compound 3.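

In this assay, this result shows that the group on the ring amine nitrogen can do more than shift the number modestly: replacing 4-fluorobenzyl with (1H-indol-2-yl)methyl gives a 15-fold higher number from compound 1 to compound 3 (1.19 log units; beyond the scatter). The same group in place of benzoyl gives a 100-fold higher number from compound 2 to compound 3 (2.00 log units; beyond the scatter), so this position clearly separates the three groups, and an aromatic ring at this nitrogen does not by itself preserve a low number. Nothing available here explains the loss.

The change adds a five-membered aromatic ring and a hydrogen-bond donor together and also removes the fluorine, so the compounds shown cannot say which of these matters. As far as these compounds go, a naphthylmethyl group on the same nitrogen would keep two aromatic rings without the donor, and its result remains open.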